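From Imidazole to Formylamino at the Side-Chain Carbon

This account rests on a few compounds, and the source may have more. Where it says the series, first, only, none or still open, it means among the compounds named here.

Measured compounds:
compound 1 `COC(=O)CC1CCN(C[C@H]2CN(c3ccc(-n4cc(-c5ccccn5)cn4)c(F)c3)C(=O)O2)CC1` — 92100 nM
compound 2 `O=C1CSC(=O)N1C[C@H]1CN(c2ccc(-n3cc(-c4ccccn4)cn3)c(F)c2)C(=O)O1` — 26900 nM
compound 3 `O=C1O[C@@H](Cn2ccnc2)CN1c1ccc(-n2cc(-c3ccccn3)cn2)c(F)c1` — 12300 nM

In a physicochemical assay for solubility, read by HPLC, with a stated time of 24 h (on this read-out lower numbers stand for lower solubility and higher numbers for higher solubility), compound 3 stands lowest of the three, with compound 2 nearest and compound 1 furthest above it. Compound 4 `O=CNC[C@H]1CN(c2ccc(-n3cc(-c4ccccn4)cn3)c(F)c2)C(=O)O1` differs from compound 3 by formylamino in place of 1H-imidazol-1-yl on a saturated chain carbon bound to a saturated ring carbon. Within the data shown here, the steps that bear on this position are a 7.5-fold lower number from compound 1 to compound 3 (0.87 log units; beyond the scatter) and a 2.2-fold lower number from compound 2 to compound 3 (0.34 log units; beyond the scatter), both modest and both falling as the group on that carbon changed. Nothing here separates the effect of a formylamino group from that of the imidazole, so compound 4 is expected to sit close to compound 3, with any step a 1.2-fold lower number from compound 3 to compound 4 (0.09 log units; within the scatter) likely within the scatter. Compound 4 is therefore estimated at 10000 nM, in the range 4000 nM to 25000 nM.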

Compound 4, solubility: 217000 nM
Beside the measured number, compound 4's estimate is 22-fold (1.34 log units) below it; the whole stated range lies below it.
By their numbers in this assay, from the lowest: compound 3; then compound 2; then compound 1; then compound 4.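

At this position the number can rise as well as fall: in this assay, formylamino in place of 1H-imidazol-1-yl gives an 18-fold higher number from compound 3 to compound 4 (1.25 log units; beyond the scatter) and this is the largest step seen on this carbon. Formylamino also stands above both other groups, with an 8.1-fold higher number from compound 2 to compound 4 (0.91 log units; beyond the scatter) and with a 2.4-fold higher number from compound 1 to compound 4 (0.37 log units; beyond the scatter) which places compound 4 highest of the four. Nothing measured here accounts for this rise. The compounds shown leave open whether an acetylamino group or a plain amine on the same carbon would keep the number this high.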